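Bromo in Place of Methyl on Compound 2

The source may report more compounds than this note shows. Statements on the series, on what has been measured and on what is new or still open speak of the compounds shown alone.

In a functional assay on HepG2 cells (Homo sapiens) for antiproliferative activity, read by MTT assay, with a stated time of 48 h (a lower number here means a stronger inhibitor, a higher number a weaker inhibitor), compound 1 `COc1ccc(CN(C(=O)Cn2cc(COc3ccc4ccc(=O)oc4c3)nn2)c2cc(OC)c(OC)c(OC)c2)cc1` gives 1300 nM, while compound 2 `COc1ccc(CN(C(=O)Cn2cc(CNS(=O)(=O)c3ccc(C)cc3)nn2)c2cc(OC)c(OC)c(OC)c2)cc1` gives 30500 nM, the higher of the two numbers. Compound 3 `COc1ccc(CN(C(=O)Cn2cc(CNS(=O)(=O)c3ccc(Br)cc3)nn2)c2cc(OC)c(OC)c(OC)c2)cc1` carries bromo in place of methyl on an aromatic carbon, para to a large group: bromo in place of methyl on an aromatic carbon. Going by the values given here, the one measured step, a 23-fold higher number from compound 1 to compound 2 (1.37 log units; beyond the scatter), was large but exchanged a whole ring-bearing group, so it bears only loosely on this smaller change. Among the compounds with values here, no measured step covers bromo in place of methyl, so no step beyond the scatter is expected, a 1.4-fold lower number from compound 2 to compound 3 (0.14 log units; within the scatter). Compound 3 is expected at 22000 nM, with an estimated range from 9000 nM to 50000 nM.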

Compound 3, half-maximal inhibitory concentration: 7370 nM
The estimate for compound 3 lay 3.0-fold (0.47 log units) above the measured number, outside the stated range (below it).
By their numbers in this assay, from the lowest: compound 1; then compound 3; then compound 2.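

In this assay the place on the aromatic ring para to a large group proved sensitive to a single-atom exchange: bromo in place of methyl gives a 4.1-fold lower number from compound 2 to compound 3 (0.62 log units; beyond the scatter) and so lies beyond the scatter. The bromo group still does not close the gap to compound 1, with a 5.7-fold higher number from compound 1 to compound 3 (0.75 log units; beyond the scatter) remaining when the whole group is exchanged. Nothing available accounts for this gain with bromo.

On these data alone, whether chloro, methoxy or an amine at this place would track bromo or methyl remains open.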